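Iodo to trifluoromethoxy on the shared core

The source may report more compounds than this note shows. Statements on the series, on what has been measured and on what is new or still open speak of the compounds shown alone.

Two compounds built on the shared core of compound 1 `COC(=O)c1ccc(SCc2ncnc3c2ncn3[C@@H]2O[C@H](CO)[C@@H](O)[C@H]2O)cc1` differ only in the group on the six-membered aromatic ring of carbon only. In an assay on isolated protein for binding affinity to Equilibrative nucleoside transporter 1 (Homo sapiens) (on this read-out lower numbers stand for stronger inhibition and higher numbers for weaker inhibition), compound 1 gives 813 nM. Going by the values given here, compound 2 `OC[C@H]1O[C@@H](n2cnc3c(CSc4ccc(I)cc4)ncnc32)[C@H](O)[C@@H]1O` gives 69.2 nM in this assay, the lowest of the two numbers known here. Among the compounds with values here, the single measured step, a 12-fold lower number from compound 1 to compound 2 (1.07 log units; beyond the scatter), shows that exchanging this one group moves the number far beyond the scatter. Compound 3 `OC[C@H]1O[C@@H](n2cnc3c(CSc4ccc(OC(F)(F)F)cc4)ncnc32)[C@H](O)[C@@H]1O` is the next member: trifluoromethoxy in place of iodo on an aromatic carbon. Within the data shown here, no measured step covers the exchange of iodo for trifluoromethoxy, so the step from compound 1 to compound 2 is the only guide, and it tells merely that this position is sensitive, not which way the new group will push the number. Compound 3 is therefore expected to land somewhat above compound 2 but well below compound 1, with wide uncertainty. In this assay compound 3 is estimated at 150 nM, between 40 nM and 600 nM. This expectation amounts to a step of a 2.2-fold higher number from compound 2 to compound 3 (0.34 log units; beyond the scatter).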

Compound 3, half-maximal inhibitory concentration: 123 nM
Compound 3: the middle estimate sits 1.2-fold (0.09 log units) above what was measured, and the stated range covers the measured number.
By their numbers in this assay, from the lowest: compounds 2 and 3 (each within the scatter of the next); then compound 1.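

In this assay, replacing iodo with trifluoromethoxy at this position, on an aromatic carbon para to a large group, swaps one heavy atom for five, yet the step of a 1.8-fold higher number from compound 2 to compound 3 (0.25 log units; within the scatter) stays within the usual scatter, so the two compounds cannot be told apart. The other new step, a 6.6-fold lower number from compound 1 to compound 3 (0.82 log units; beyond the scatter), lies beyond the scatter and shows that the large gain seen with iodo is not unique to that group: a second replacement for methoxycarbonyl also gives a clearly lower number, and among these three compounds methoxycarbonyl alone stands apart. Nothing available here explains why these two groups read alike or why methoxycarbonyl differs from both.

What the three compounds leave open is whether this tolerance extends to groups of another kind at the same place, such as an amine, a carboxylic acid or a simple methyl group, or to the bare ring carrying only hydrogen. They also cannot show which part of methoxycarbonyl goes with its higher number, a question that a free carboxylic acid or a methyl ketone at this position could help to address.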